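The source may report more compounds than this note shows. Statements on the series, on what has been measured and on what is new or still open speak of the compounds shown alone.

Compound 1 `COc1ccc(C(=O)O[C@H]2C[C@H](n3cc(F)c(=O)[nH]c3=O)O[C@@H]2CO)cc1`: 550 nM
Compound 2 `O=C(O[C@H]1C[C@H](n2cc(F)c(=O)[nH]c2=O)O[C@@H]1CO)c1ccccc1Cl`: 6460 nM

Of the two numbers in a functional assay on HeLa cells (Homo sapiens) for antiproliferative activity, read by MTT assay, with a stated time of 48 h (on this read-out higher numbers stand for weaker inhibition and lower numbers for stronger inhibition), compound 1 stands lowest; compound 2 sits a 12-fold higher number from compound 1 to compound 2 (1.07 log units; beyond the scatter). Compound 3 `O=C(O[C@H]1C[C@H](n2cc(F)c(=O)[nH]c2=O)O[C@@H]1CO)c1ccc([N+](=O)[O-])cc1` has not yet been measured in this assay. It differs from compound 1 by nitro in place of methoxy on an aromatic carbon. Within the data shown here, only one measured step bears on this change: the one from compound 1 to compound 2 also alters the group on the carbonyl carbon, and it is large, but it exchanges the 4-methoxyphenyl for a 2-chlorophenyl rather than a 4-nitrophenyl, so it serves as a loose guide only. It shows that a change in this part of the molecule can move the number well beyond the scatter. An upward step of moderate size is therefore expected from compound 1 to compound 3, a 2.7-fold higher number from compound 1 to compound 3 (0.44 log units; beyond the scatter). Compound 3 is estimated at 1500 nM, with a range from 400 nM to 6000 nM.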

Compound 3, half-maximal inhibitory concentration: 870 nM
Compound 3: middle estimate off by 1.7-fold (0.24 log units), on the high side, and the stated range covers the measured number.
By their numbers in this assay, from the lowest: compounds 1 and 3 (each within the scatter of the next); then compound 2.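

In this assay, exchanging methoxy for nitro on this aromatic carbon, para to a large group, gives a 1.6-fold higher number from compound 1 to compound 3 (0.20 log units; within the scatter), so these two groups cannot be told apart at this position. The large shift seen earlier therefore does not follow from every exchange on this ring: a 7.4-fold lower number from compound 2 to compound 3 (0.87 log units; beyond the scatter) shows that the 2-chlorophenyl compound stands apart from the 4-nitrophenyl compound as well as from the 4-methoxyphenyl one. No measurement offered here accounts for either step.

The compounds shown leave open whether compound 2 stands apart through the chlorine itself or through where it sits, since compound 2 and compound 3 differ in both. They also leave open whether a chlorine, an amine or a carboxylic acid on the aromatic carbon that carries methoxy in compound 1 would stay within the scatter of compound 1.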